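Dropping the Nitrile from the Phenyl Ring of Compound 1

The compounds below may be only part of what the source reports. "The series", "measured", "known", "first", "only" and "open" are said of these compounds alone.

Compound 1 `N#Cc1ccc(NC(=S)N/N=C/c2ccc3ccccc3n2)cc1` was tested in a functional assay on HT-29 cells (Homo sapiens) for antiproliferative activity, read by sulforhodamine B assay, with a stated time of 72 h (on this read-out higher numbers stand for weaker inhibition and lower numbers for stronger inhibition), where compound 1 gives 15600 nM, the highest of the two numbers shown. Compound 2 `CN(C)C(=S)N/N=C/c1cnc2ccccc2n1` gives 450 nM in this assay, a much lower number, beyond the scatter. Compound 3 `NC(=S)N/N=C/c1cnc2ccccc2n1` reaches only the limit > 100000 nM in this assay. Among the measured compounds shown here, the single measured step, an at least 220-fold higher number from compound 2 to compound 3 (2.34 log units; beyond the scatter), concerns the amine attached to the thiocarbonyl, not the aromatic ring. Compound 4 `S=C(N/N=C/c1ccc2ccccc2n1)Nc1ccccc1` differs from compound 1 by hydrogen in place of cyano on an aromatic carbon. For the measured compounds named here, no measured step touches this part of the structure, so no shift beyond the scatter is expected in this assay. Compound 4 is therefore estimated at 12000 nM, between 4000 nM and 40000 nM. The expected change is a 1.3-fold lower number from compound 1 to compound 4 (0.11 log units; within the scatter).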

Compound 4, half-maximal inhibitory concentration: 17000 nM
Estimate against measurement, compound 4: 1.4-fold (0.15 log units) below; the range from low to high includes it.
By their numbers in this assay, from the lowest: compound 2; then compounds 1 and 4 (each within the scatter of the next). At a limit, above all of these: compound 3.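

Within this assay the step on the aromatic ring is a 1.1-fold higher number from compound 1 to compound 4 (0.04 log units; within the scatter) and gives the first measured look at this position, para to a large group. Among the compounds shown here, the nitrile can thus give way to hydrogen here without a shift beyond the scatter, whereas the only earlier step concerned the amine on the thiocarbonyl. Nothing measured here speaks to why this change leaves the number within the scatter.

The compounds shown leave open whether an amine or a carboxylic acid at this position would move the number. They also leave open whether the same change would hold on a different core.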